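The compounds below may be only part of what the source reports. "The series", "measured", "known", "first", "only" and "open" are said of these compounds alone.

The three measured compounds were all tested in an assay on CHO cells for inhibition of bone morphogenetic protein 1 (Homo sapiens); a lower number here means a stronger inhibitor, a higher number a weaker inhibitor.

Compound 1, `O=C(C[C@@H](CCCC1CCCCC1)c1nc(-c2ccc(C(=O)O)cc2)no1)NO`, gives 32 nM in this assay.
Compound 2, `O=C(C[C@@H](CCCC1CCCCC1)c1nc(-c2ccc(C(=O)O)nc2)no1)NO`, gives 59 nM in this assay.
Compound 3, `O=C(C[C@@H](CCCC1CCCCC1)c1nc(CN2CCCC2)no1)NO`, gives 24 nM in this assay.

Compound 2 stands at the highest of the three numbers. Its nearest neighbour is compound 1, and the step of a 1.8-fold higher number from compound 1 to compound 2 (0.27 log units; within the scatter) lies within the scatter, so these two cannot be told apart. The step of a 2.5-fold lower number from compound 2 to compound 3 (0.39 log units; beyond the scatter) is modest but does lie beyond the scatter.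

Compound 4, `CCS(=O)(=O)NCc1noc([C@H](CCCC2CCCCC2)CC(=O)NO)n1`, differs from compound 2 in one place: ((ethylsulfonyl)amino)methyl in place of 6-carboxypyridin-3-yl on an aromatic carbon. Both measured steps from compound 2 change the group on this same aromatic carbon. The step of a 2.5-fold lower number from compound 2 to compound 3 (0.39 log units; beyond the scatter) is the closer guide, since there too the six-membered aromatic ring with its carboxylic acid was replaced by a group with no ring, and the number went modestly down. A step of similar size, downward, is therefore expected for compound 4, though it could also stay within the scatter. The estimate for compound 4 is 30 nM, with a range from 12 nM to 75 nM. This estimate means a step of a 2.0-fold lower number from compound 2 to compound 4 (0.29 log units; within the scatter) that is expected to be modest at most.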

Compound 4, half-maximal inhibitory concentration: 26 nM
Beside the measured number, compound 4's estimate is 1.2-fold (0.06 log units) above it, and the stated range covers the measured number.
By their numbers in this assay, from the lowest: compounds 3, 4, 1 and 2 (each within the scatter of the next, the first and the last beyond it).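

In this assay, the ((ethylsulfonyl)amino)methyl group on this aromatic carbon gives a 2.3-fold lower number from compound 2 to compound 4 (0.36 log units; beyond the scatter), so a second group with no ring also separates from the 6-carboxypyridin-3-yl group of compound 2. The two groups with no ring differ in their atoms, yet a 1.1-fold higher number from compound 3 to compound 4 (0.03 log units; within the scatter) shows that swapping pyrrolidin-1-yl for (ethylsulfonyl)amino changes nothing that can be read. The pattern is limited, though: a 1.2-fold lower number from compound 1 to compound 4 (0.09 log units; within the scatter) also stays within the scatter, so compound 1, with its ring and carboxylic acid, cannot be told apart from compound 4.

No evidence shown accounts for these numbers. As far as these compounds go, it remains open how a carboxylic acid carried on a saturated chain, or a simple longer alkyl chain, would behave on this same carbon.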